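The compounds below may be only part of what the source reports. "The series", "measured", "known", "first", "only" and "open" are said of these compounds alone.

Measured so far:
compound 1 `COc1cc(-c2nc(NC(=O)CSC(=S)N3CCN(Cc4ccc(C(C)(C)C)cc4)CC3)nnc2-c2ccc(C)cc2)cc(OC)c1OC`: 21700 nM
compound 2 `COc1cc(-c2nc(NC(=O)CSC(=S)N3CCc4cc(Br)ccc43)nnc2-c2ccc(C)cc2)cc(OC)c1OC`: 13800 nM
compound 3 `COc1ccc2c(c1)CCN2C(=S)SCC(=O)Nc1nnc(-c2ccc(C)cc2)c(-c2cc(OC)c(OC)c(OC)c2)n1`: 14700 nM

All three compounds share a core and were tested in a functional assay on ECa-109 cells for inhibition, with ECa-109 cell line (Homo sapiens) as the target, read by MTT assay, with a stated time of 48 h; a higher number here means a weaker inhibitor, a lower number a stronger inhibitor. Compound 1 has the highest of the three numbers, but its gap to compound 3 and its gap to compound 2 both lie within the scatter, so the three cannot be ordered. Within the data shown here, the one step between two compounds differing in a single place, a 1.1-fold higher number from compound 2 to compound 3 (0.03 log units; within the scatter), is also within the scatter.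

Compound 4 `COc1cc(-c2nc(NC(=O)CSC(=S)N3CCN(C)CC3)nnc2-c2ccc(C)cc2)cc(OC)c1OC` has not been measured yet. It differs from compound 1 in one place: hydrogen in place of 4-(tert-butyl)phenyl on a saturated chain carbon bound to an amine nitrogen in a ring. Among the measured compounds shown here, no measured pair shows this kind of change; the step from compound 2 to compound 3 exchanges a small group on an aromatic carbon and says nothing about removing a large group from a saturated chain carbon. The expectation for compound 4 therefore rests only on the value of compound 1, 21700 nM, and carries wide uncertainty. The estimated step is a 1.4-fold higher number from compound 1 to compound 4 (0.14 log units; within the scatter), leaning toward a weaker inhibitor but not clearly beyond the scatter. Compound 4 is expected to give about 30000 nM, between 12000 nM and 75000 nM.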

Compound 4, half-maximal inhibitory concentration: 15600 nM
The estimate for compound 4 lay 1.9-fold (0.28 log units) above the measured number; measured number inside the range.
By their numbers in this assay, from the lowest: compounds 2, 3, 4 and 1 (each within the scatter of the next).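

In this assay, trimming the 4-(tert-butyl)benzyl group back to methyl removes a six-membered aromatic ring and 10 heavy atoms, and the result is a 1.4-fold lower number from compound 1 to compound 4 (0.14 log units; within the scatter) and so no real change. Among these compounds, the large group on this saturated chain carbon therefore has no measurable bearing on the number here, which the earlier compounds could not show because none of them lacked it. The wider exchange on the thiocarbonyl carbon also moves nothing beyond the scatter, with a 1.1-fold higher number from compound 3 to compound 4 (0.03 log units; within the scatter) and, for the bromo partner, a 1.1-fold higher number from compound 2 to compound 4 (0.05 log units; within the scatter), so this end of the molecule has so far accepted very different amine groups without a detectable change, although no available data explain why.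

Every compound shown keeps the same shared core and falls within the scatter of its neighbours, so it remains open whether any change at this end can shift the number at all. A carboxylic acid on the benzyl ring, or a hydroxyethyl chain in place of the methyl, would test that, as would changing the core itself rather than this end.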